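Trading Chloro for Hydrogen: Expected Effect on Efficacy

The compounds below may be only part of what the source reports. "The series", "measured", "known", "first", "only" and "open" are said of these compounds alone.

Among the measured compounds shown here, compound 1 `O=C(O)Cc1sc(C(c2ccc(F)cc2)c2ccc(F)cc2)nc1-c1ccnc(Cl)c1` gives 80% in an in vitro functional assay on HEK285-7 cells for antagonist activity at prostaglandin D2 receptor 2 (Homo sapiens), read by BRET and beta-arrestin recruitment (a lower number here means a smaller maximal response, a higher number a larger maximal response), the higher of the two numbers measured so far. Compound 2 `Cc1nc(-c2ccc(Cl)cc2)c(CC(=O)O)s1`, which rests on a different core, gives 50% in this assay; its number sits below compound 1 by more than the usual scatter of this kind of measurement.

Compound 3 `O=C(O)Cc1sc(C(c2ccc(F)cc2)c2ccc(F)cc2)nc1-c1ccncc1` has not yet been measured. It differs from compound 1 in one place: hydrogen in place of chloro on an aromatic carbon. Cut one bond further out, the change reads 2-chloropyridin-4-yl to pyridin-4-yl.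

For the measured compounds named here, no pair of measured compounds shows what such a swap does here, so the expectation rests on compound 1 alone. Because compound 1 reaches 80%, compound 3 is expected to stay close to it, and the step of a number 5 percentage points lower from compound 1 to compound 3 (within the scatter) is expected to lie within the scatter, with no clear direction. Compound 3 is therefore estimated at 75%, with a range from 55% to 95%.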

Compound 3, largest response reached (reported as efficacy), in percent of the reference or control that the assay uses: 80%
Beside the measured number, compound 3's estimate is 5 percentage points below it; measured number inside the range.
By their numbers in this assay, from the lowest: compound 2; then compounds 1 and 3 (each within the scatter of the next).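

In this assay the swap of chloro for hydrogen, on the aromatic carbon next to the ring nitrogen, gives no change at the digits printed from compound 1 to compound 3 (within the scatter). Among the compounds shown here, this is the first direct reading of a single change on this core: in this read-out, the chloro group is not needed to hold the maximal response at this level, and a plain pyridin-4-yl serves as well as 2-chloropyridin-4-yl. Nothing shown here explains why the number holds.

One swap tests only two substituents at one carbon, so a methyl, a methoxy or an amine at the same place could still give a clearly different number. The pair also says nothing about how changes elsewhere in compound 3, such as replacing either fluoro group, would affect the response.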